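The source may report more compounds than this note shows. Statements on the series, on what has been measured and on what is new or still open speak of the compounds shown alone.

Four compounds share one core and differ only in a single group attached to it. Compound 1 `CCCCSc1nc(N)nc2c1ncn2/C=C1/CC1(CO)CO` and compound 2 `CCCOc1nc(N)nc2c1ncn2/C=C1/CC1(CO)CO` were tested in an ADME assay on MOLT-3 cells (Homo sapiens) for cytotoxicity, with a stated time of 7 days; on this read-out higher numbers stand for lower toxicity in this test and lower numbers for higher toxicity in this test. Compound 1 gives only a limit there, > 20000 nM. Compound 2 likewise reaches only a limit, > 20000 nM. The step that the two limits leave unreadable from compound 1 to compound 2 therefore cannot be read; both results are described by the limit of > 20000 nM in this assay, at which 2 of the 3 values shown sit. For compound 3 `Nc1nc(N2CCCC2)c2ncn(/C=C3/CC3(CO)CO)c2n1` the result in this assay is "not determined" (no result reported), so compound 3 stands nowhere on the numbers shown. Going by the values given here, the only two values that exist are limits. Compound 4 `Nc1nc(NC2CCCC2)c2ncn(/C=C3/CC3(CO)CO)c2n1` has yet to be tested. It differs from compound 3 by cyclopentylamino in place of pyrrolidin-1-yl on an aromatic carbon. Among the compounds with values here, no measured step bears on this change: the one step that was measured is unreadable, and compound 3 itself has no number. The size and direction of the step in this assay therefore cannot be predicted from these data. Because both tested compounds sit at the limit of > 20000 nM in this assay, at which 2 of the 3 values shown sit, compound 4 is expected to give 20000 nM, in a range from 5000 nM to 60000 nM, most likely again as a limit.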

Compound 4, half-maximal cytotoxic concentration: > 20000 nM
Compound 4 gave a limit, no number; the forecaster's own chance of this, stated with the estimate: 70%; the middle value sits exactly at the limit.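

Going by these compounds alone, compound 1, compound 2 and compound 4 each give only a limit in this assay, so no step among them can be read: the limit of > 20000 nM in this assay, at which 3 of the 4 values shown sit. The compounds shown leave open whether changing the single group on the shared core alters toxicity in this test at all.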